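Taking the phenyl off compound 2

The source may hold more compounds than are shown below. What is called first, only, known or untested is meant among the compounds shown, and "the series" means these compounds.

Measured so far in a functional assay on HeLa cells (Homo sapiens) for antiproliferative activity, read by MTT assay, with a stated time of 72 h; on this read-out higher numbers stand for weaker inhibition and lower numbers for stronger inhibition:
- compound 1 `NC(=S)N/N=C/c1ccccc1O`: >= 5000 nM (a limit, not a number)
- compound 2 `COc1cccc(/C=N/NC(=S)Nc2ccccc2)c1O`: 1700 nM
- compound 3 `Oc1ccccc1/C=N/NC(=S)Nc1ccccc1`: 1500 nM

Compound 2 gives 1700 nM and compound 3 gives 1500 nM, two values that lie within the scatter of each other. Going by the values given here, the only other reading, for compound 1, is a limit of the assay.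

Compound 4 `COc1cccc(/C=N/NC(N)=S)c1O` is compound 2 with a single change: hydrogen in place of phenyl on an amide-type nitrogen, (hydrogen in place of phenyl on an amide-type nitrogen).

Among the compounds with values here, two measured steps bear on this change. The same swap run in the opposite direction, phenyl in place of hydrogen on an amide-type nitrogen, gave an at least 3.3-fold lower number from compound 1 to compound 3 (0.52 log units; beyond the scatter) in this assay. The other step concerns the methoxy group that sets compound 4 apart from compound 1, and it gave a 1.1-fold lower number from compound 2 to compound 3 (0.05 log units; within the scatter). Compound 1 is therefore a fair guide to compound 4, and removing the phenyl is expected to raise the number, meaning weaker inhibition, by a step beyond the scatter.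

The expected change is a 3.8-fold higher number from compound 2 to compound 4 (0.58 log units; beyond the scatter). Like compound 1, compound 4 may well be reported only as a limit. The estimate for compound 4 is 6500 nM, with an expected range from 3000 nM to 15000 nM.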

Compound 4, half-maximal inhibitory concentration: >= 5000 nM
Compound 4: no number, only a limit (the forecaster's own chance of this, stated with the estimate: 60%); the middle value is on the limit's open side.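

In this assay, hydrogen in place of phenyl on the amide-type nitrogen gives an at least 2.9-fold higher number from compound 2 to compound 4 (0.46 log units; beyond the scatter), which means weaker inhibition once the anilino group becomes a plain amino group. The phenyl therefore counts on the methoxy-bearing core as well, and the change runs in the same direction on both cores: the same change on two cores in this assay, an at least 3.3-fold lower number (0.52 log units; beyond the scatter) from compound 1 to compound 3 and an at least 2.9-fold lower number (0.46 log units; beyond the scatter) from compound 4 to compound 2; the limit leaves it open whether they differ

For compound 4, the reading of >= 5000 nM is a limit, not a number.

The step from compound 1 to compound 4 cannot be read, so what the methoxy group does on the core without the phenyl stays open, as both compounds sit at the same limit: the limit of >= 5000 nM in this assay, at which 2 of the 4 values shown sit.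

Going by these compounds, it also stays open whether this nitrogen needs an aromatic ring at all, since a methyl group or a cyclohexyl ring in the same place would show whether any carbon group can stand in for the phenyl, or only a flat aromatic one.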